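The source may report more compounds than this note shows. Statements on the series, on what has been measured and on what is new or still open speak of the compounds shown alone.

Measured so far:
compound 1 `CC(C)CCCN(C(=O)[C@@H]1C[C@H]1c1ccccc1)c1ccc(-c2ccccc2)cc1` — > 100 nM
compound 2 `CC[C@H](C)[C@H](N)CN(C(=O)[C@@H]1C[C@H]1c1ccc(F)c(F)c1)c1ccc(-c2ccccc2)cc1` — 720 nM

In a functional assay for agonist activity at G protein-coupled receptor 88 (Homo sapiens), read by HTRF and cAMP accumulation (a lower number here means that less compound is needed, a higher number that more compound is needed for the effect), compound 1 comes back only as a limit, > 100 nM, not as a number. Among the measured compounds shown here, compound 2 `CC[C@H](C)[C@H](N)CN(C(=O)[C@@H]1C[C@H]1c1ccc(F)c(F)c1)c1ccc(-c2ccccc2)cc1` is the one compound with a real number in this assay, 720 nM. Its place relative to compound 1 cannot be fixed, as the comparison rests on (the limit of > 100 nM in this assay, at which 1 of the 2 values shown sits).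

Compound 3 `CC[C@H](C)[C@H](N)CN(C(=O)[C@@H]1C[C@H]1c1csc(C)n1)c1ccc(-c2ccccc2)cc1` has not yet been measured. It differs from compound 2 in one place: 2-methyl-1,3-thiazol-4-yl in place of 3,4-difluorophenyl on a saturated ring carbon. For the measured compounds named here, no step between two measured compounds is available to show how this assay responds to an exchange of this kind, so the direction of the change cannot be read from the data at hand. The expectation for compound 3 is therefore kept near compound 2, with wide room on both sides: compound 3 is estimated at 1500 nM, within 400 nM to 6000 nM. The step this means, a 2.1-fold higher number from compound 2 to compound 3 (0.32 log units; beyond the scatter), is expected to be small and may not reach beyond the usual scatter.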

Compound 3, half-maximal effective concentration: 1500 nM
Compound 3: middle estimate and measured number agree at the digits printed, and the stated range covers the measured number.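

In this assay, the exchange on the saturated ring carbon gives a 2.1-fold higher number from compound 2 to compound 3 (0.32 log units; beyond the scatter), a modest step but the first that can be read at this position. It shows that a measurable number survives when the six-membered aromatic ring of carbon only gives way to a smaller five-membered aromatic ring with 2 hetero atoms and 2 hydrogen-bond acceptors, so activity here does not depend on keeping the 3,4-difluorophenyl group intact. Yet this single step changes ring size, hetero atoms and substituents all at once, and nothing measured here gives a reason for the higher number.

Compound 1 gives > 100 nM, which is a limit and not a number, and any step involving it cannot be read. The compounds shown leave open which part of the exchange carries the step, and an unsubstituted 1,3-thiazol-4-yl group or a pyridine ring on the same ring carbon would separate the loss of the methyl group and the sulfur atom from the change in ring size.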